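This account rests on a few compounds, and the source may have more. Where it says the series, first, only, none or still open, it means among the compounds named here.

Values measured so far in a functional assay on HL-60 cells (Homo sapiens) for inhibition, read by MTT assay, with a stated time of 48 h, tested at 10 uM (a lower number here means less inhibition of growth, a higher number more inhibition of growth at the concentration tested), are these:

- compound 1 `Cc1cc(=O)c2c(O)c(CN3CCCC3CO)c(O)c([C@H]3CCN(C)C[C@H]3O)c2o1` gives 33% 
- compound 2 `Cc1oc2c([C@H]3CCN(C)C[C@H]3O)c(O)cc(O)c2c(=O)c1C(O)c1c(Cl)cccc1Cl` gives 14% 

Compound 2 (14%) holds the lower of the two numbers, and compound 1 (33%) stands above it by more than the usual scatter. These two compounds differ in more than one place, so their gap says nothing direct about a single exchange.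

The next compound to read is compound 3 `Cc1oc2c([C@H]3CCN(C)C[C@H]3O)c(O)cc(O)c2c(=O)c1C(O)c1ccc(F)cc1`, which keeps the rest of compound 2 and carries 4-fluorophenyl in place of 2,6-dichlorophenyl on a saturated chain carbon bound to an aromatic carbon and an oxygen on a saturated carbon. Going by the values given here, no measured pair isolates this exchange. The starting point is therefore compound 2 (14%), and only a small upward move in this assay is expected, probably not beyond the scatter. The estimated a number 5 percentage points higher from compound 2 to compound 3 (within the scatter) is correspondingly modest and uncertain. For compound 3 the expected value is 19% (estimated range 6% to 36%) on this reading.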

Compound 3, percent growth inhibition at one concentration: 30%
Estimate against measurement, compound 3: 11 percentage points below, and the stated range covers the measured number.
By their numbers in this assay, from the lowest: compound 2; then compounds 3 and 1 (each within the scatter of the next).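

In this assay, going by these compounds alone, the exchange of 2,6-dichlorophenyl for 4-fluorophenyl, on a saturated chain carbon bound to an aromatic carbon and an oxygen on a saturated carbon, gives a number 16 percentage points higher from compound 2 to compound 3 (beyond the scatter), and this is the first comparison that isolates one place. With the rest of compound 2 held fixed, growth inhibition at the concentration tested therefore responds to the aromatic group at this position, even though the two groups match in their ring, their counts of hydrogen-bond donors and acceptors, and their lack of net charge. No data at hand bear on the reason for this step, so it stands as an observation only.

The two compounds cannot separate the removal of the two chlorines from the introduction of the fluorine, nor does a single pair show whether the change depends on where the halogens sit on the ring. Unsubstituted phenyl, 4-chlorophenyl and 2,6-difluorophenyl at this position would each address that question, and how a pyridine ring or an amine would read here also remains open.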